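The compounds below may be only part of what the source reports. "The series", "measured", "known", "first", "only" and "open" are said of these compounds alone.

Measured so far:
- compound 1, `C[S+]([O-])/C=C/c1cc(=O)c2cc(Cl)ccc2o1`: 6500 nM
- compound 2, `CC(C)Oc1ccc2oc(/C=C/[S+](C)[O-])cc(=O)c2c1`: 8000 nM

Both were tested in a functional assay on DLD-1 cells (Homo sapiens) for cytotoxicity, with a stated time of 48 h; a higher number here means a weaker inhibitor, a lower number a stronger inhibitor. Compound 1 gives 6500 nM and compound 2 gives 8000 nM. Among the compounds with values here, the only step between measured compounds, a 1.2-fold higher number from compound 1 to compound 2 (0.09 log units; within the scatter), is within the usual scatter, so the two numbers cannot be told apart: compound 2 stands level with compound 1, not above or below it.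

Compound 3, `COc1ccc2oc(/C=C/[S+](C)[O-])cc(=O)c2c1`, differs from compound 2 in one place: methyl in place of isopropyl on an oxygen on an aromatic ring. Within the data shown here, the only measured step, a 1.2-fold higher number from compound 1 to compound 2 (0.09 log units; within the scatter), touched the same position of the shared core and changed the whole group there, yet it moved the number by less than the scatter. The step to compound 3 is a smaller edit still, trimming the chain on the oxygen without adding or removing any donor or acceptor. Among the measured compounds shown here, no measured step speaks for a shift in either direction, so the expected step of no change at the digits printed from compound 2 to compound 3 (within the scatter) is none beyond the scatter. Compound 3 is therefore estimated at 8000 nM, with a range from 3500 nM to 18000 nM.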

Compound 3, half-maximal inhibitory concentration: 5700 nM
The estimate for compound 3 lay 1.4-fold (0.15 log units) above the measured number; low and high end bracket the measured number.
By their numbers in this assay, from the lowest: compounds 3, 1 and 2 (each within the scatter of the next).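

In this assay, trimming isopropoxy to methoxy (a 1.4-fold lower number from compound 2 to compound 3 (0.15 log units; within the scatter)) and putting methoxy in place of chloro (a 1.1-fold lower number from compound 1 to compound 3 (0.06 log units; within the scatter)) both stay within the scatter, as did the earlier swap of chloro for isopropoxy. Compounds 1, 2 and 3 therefore stand level, and the earlier result now extends to a third group at this position: chloro, methoxy and isopropoxy on this aromatic carbon cannot be told apart here, and the shorter methyl on the oxygen gives a number no different from the isopropyl. Nothing available explains why these groups give such similar numbers.

On these data alone, whether this flat picture would hold for quite different groups on the same carbon, such as an amine, a carboxylic acid or a longer chain on the oxygen, remains open. The rest of the molecule is identical in all three compounds, so how the number responds to edits elsewhere on the shared core is also unknown.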